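Aryloxypropyl triazine series: a second chloro on compound 2

A few compounds are considered here, and "the series" means these few. Any claim that something is new, unique, unknown or untested is made for them only; others in the source may bear on it.

Measured compounds:
compound 1 `NC1=NC2(CCOCC2)N(OCCCOc2cc(Cl)c(Cl)cc2Cl)C(N)=N1`: > 90%
compound 2 `NC1=NC2(CCSCC2)N(OCCCOc2ccc(Cl)cc2)C(N)=N1`: > 90%
compound 3 `COc1ccc(OCCCON2C(N)=NC(N)=NC23CCOCC3)cc1`: > 90%

In an assay on isolated protein for inhibition of Dihydrofolate reductase (Homo sapiens), read by spectrophotometry, using NADPH, with stated times of 5 s and 6 min, tested at 5 uM (a higher number here means a stronger effect of the compound at the concentration tested, a lower number a weaker effect), compound 1 gives > 90%, which is a limit of the assay and not a number. Compound 2 gives > 90%, also a limit. Compound 3 gives > 90%, again a limit. All three values sit at the limit of > 90% in this assay, at which 3 of the 3 values shown sit, so none of the three can be ordered against another. Going by the values given here, the only step between compounds differing in one place, a step that the two limits leave unreadable from compound 1 to compound 3, is unreadable because both of its ends are limits.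

Compound 2 therefore stands at the limit, indistinguishable from compound 1 and compound 3 on the numbers shown.

Compound 4 `NC1=NC2(CCSCC2)N(OCCCOc2ccc(Cl)c(Cl)c2)C(N)=N1` differs from compound 2 by chloro in place of hydrogen on an aromatic carbon. Among the compounds with values here, no measured step bears directly on this change, and the one step available, a step that the two limits leave unreadable from compound 1 to compound 3, gives no readable size. Because every measured compound sits at the limit of > 90% in this assay, at which 3 of the 3 values shown sit, compound 4 is expected to sit at the limit as well, and the expected step that the limit leaves unreadable from compound 2 to compound 4 should lie within the scatter. The estimate for compound 4 in this assay is 95%, with a range from 85% to 100%.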

Compound 4, a percentage reported as inhibition, at one concentration (the size of the read-out at that concentration, not a potency): 88.4%
Estimate against measurement, compound 4: 6.6 percentage points above; the measured number falls inside the stated range.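

In this assay, going by these compounds alone, compound 4 gives 88.4%, the only value in the set that is a number and not a limit, so this 3,4-dichlorophenyl compound offers the first reading that could register a change in either direction. Going from 4-chlorophenyl to 3,4-dichlorophenyl, with the new chloro ortho to a chloro group and meta to a large group, gives a number at least 1.6 percentage points lower from compound 2 to compound 4 (that floor lies within the scatter), so the numbers show no loss beyond the usual scatter for this change, while its true size stays unknown. The remaining compounds give no number to set against compound 4, and the series therefore still has almost no readable range in this assay: the limit of > 90% in this assay, at which 3 of the 4 values shown sit.

The other step in the set cannot be read, which leaves the effect of changing the aryl substituents on the core of compound 1 unresolved. Also open, going by these compounds, is how this assay would respond to an amine or a carboxylic acid on this aromatic carbon, or to a longer chain on the oxygen in place of the propyl chain.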